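Swapping a Pyridyl Arm for a Methoxyphenyl Arm

The source may hold more compounds than are shown below. What is called first, only, known or untested is meant among the compounds shown, and "the series" means these compounds.

Four ureas share one core and are followed in a functional assay on HEK293 cells for antagonist activity at transient receptor potential cation channel subfamily V member 1 (Homo sapiens), read by FLIPR; on this read-out lower numbers stand for stronger inhibition and higher numbers for weaker inhibition. Compound 1 `O=C(Nc1cccc2cnccc12)NC1CCc2cc(Br)ccc2C1Cc1ccccc1` gives 17 nM, and compound 2 `O=C(Nc1cccc2cnccc12)NC1CCc2cc(F)ccc2C1Cc1ccoc1` gives 83 nM. Compound 3 `COc1ccc2c(c1)CCC(NC(=O)Nc1cccc3cnccc13)C2Cc1cccnc1` reaches only the limit of this assay, > 1000 nM, which is a boundary rather than a number. Among the three values shown, compound 3 is the one sitting at the limit of > 1000 nM in this assay, at which 1 of the 3 values shown sits. Compound 4 `COc1ccc(CC2c3ccc(OC)cc3CCC2NC(=O)Nc2cccc3cnccc23)cc1` has not been measured yet; it differs from compound 3 by 4-methoxyphenyl in place of pyridin-3-yl on a saturated chain carbon bound to a saturated ring carbon. Among the measured compounds shown here, no measured pair shows this exact change, so the expected size of the step from compound 3 to compound 4 rests on the potent values of compound 1 and compound 2, which carry carbon-only or furan arms; a gain beyond the scatter is expected, an at least 2.5-fold lower number from compound 3 to compound 4 (0.39 log units; beyond the scatter). Compound 4 is therefore estimated at 400 nM, with a likely range from 60 nM to 2000 nM.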

Compound 4, half-maximal inhibitory concentration: 36 nM
Compound 4: the middle estimate sits 11-fold (1.05 log units) above what was measured; measured number below the stated range.
By their numbers in this assay, from the lowest: compound 1; then compound 4; then compound 2. At a limit, above all of these: compound 3.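

On a saturated chain carbon bound to a saturated ring carbon, 4-methoxyphenyl in place of pyridin-3-yl gives an at least 27-fold lower number from compound 3 to compound 4 (1.44 log units; beyond the scatter) in this assay. This is the first pair shown in which only this arm changes, and that single change is enough to bring compound 4 to 36 nM. Compound 3 stands at a limit, so the step is a floor and not an exact size: the limit of > 1000 nM in this assay, at which 1 of the 4 values shown sits.

The compounds shown do not separate the loss of the ring nitrogen from the gain of the methoxy group. A 4-chlorophenyl arm on the same core would help to tell these apart.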